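A long chain added to compound 1

This account rests on a few compounds, and the source may have more. Where it says the series, first, only, none or still open, it means among the compounds named here.

Within the data shown here, in a functional assay on SW480 cells (Homo sapiens) for antiproliferative activity, read by MTT assay, with a stated time of 48 h (on this read-out higher numbers stand for weaker inhibition and lower numbers for stronger inhibition), compound 1 (`CC(CCO)n1cnc2c(Cl)nc(F)nc21`) gives 16800 nM, within the scatter of compound 3 (`CCCCCCC(CCO)n1c(Br)nc2c(Cl)ncnc21`) at 14100 nM; these are the only two numbers at hand. Compound 2 (`CC(CCO)n1cnc2c(Cl)ncnc21`) gives > 50000 nM, which is a limit of the assay. Compound 4 (`CCCCCCCCCC(CCO)n1cnc2c(Cl)nc(F)nc21`), not yet measured, differs from compound 1 by octyl in place of hydrogen on a saturated chain carbon, two bonds along the chain from an aromatic nitrogen. Among the measured compounds shown here, the one measured step, an at least 2.9-fold higher number from compound 1 to compound 2 (0.47 log units; beyond the scatter), concerns hydrogen in place of fluoro and does not touch this change. Compound 3 has a longer chain on that carbon but also differs elsewhere, and it gives 14100 nM without the fluoro, which is only indirect support. A modest step to a lower number is therefore expected, estimated as a 2.4-fold lower number from compound 1 to compound 4 (0.38 log units; beyond the scatter). Compound 4 is estimated at 7000 nM, with an expected range of 2500 nM to 20000 nM.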

Compound 4, half-maximal inhibitory concentration: 12500 nM
Estimate against measurement, compound 4: 1.8-fold (0.25 log units) below, within the range that was stated.
By their numbers in this assay, from the lowest: compounds 4, 3 and 1 (each within the scatter of the next). At a limit, above all of these: compound 2.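

In this assay, octyl in place of hydrogen on this saturated chain carbon leaves the number within the scatter: a 1.3-fold lower number from compound 1 to compound 4 (0.13 log units; within the scatter). Among these compounds, this is the first direct reading of the change, as compound 3 differs from compound 1 in more than one place, and it shows that the octyl chain is accommodated here without a gain that can be told from the scatter. Nothing at hand accounts for this result. Going by these compounds, it remains open whether a butyl chain or an amine on this carbon would give a step beyond the scatter.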